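The source may hold more compounds than are shown below. What is called first, only, known or untested is meant among the compounds shown, and "the series" means these compounds.

Measured in a functional assay on V79 cells (Cricetulus griseus) for cytotoxicity, read by colony formation; on this read-out lower numbers stand for stronger inhibition and higher numbers for weaker inhibition:
- compound 1 `O=C(O)c1cn(C2CC2)c2c(F)c(N3CCCC3)c(F)cc2c1=O`: 120 ug/mL
- compound 2 `COc1c(N2CCCC2)c(F)cc2c(=O)c(C(=O)O)cn(C3CC3)c12`: 150 ug/mL

For the measured compounds named here, compound 1 has only one measured neighbour, compound 2, and the two values lie within the scatter of each other, so neither can be ranked ahead. Compound 3 `NC1CCN(c2c(F)cc3c(=O)c(C(=O)O)cn(C4CC4)c3c2F)CC1` has not yet been measured. It keeps the core of compound 1 but carries 4-aminopiperidin-1-yl in place of pyrrolidin-1-yl on an aromatic carbon, ortho to two fluoro groups: 4-aminopiperidin-1-yl in place of pyrrolidin-1-yl on an aromatic carbon.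

Going by the values given here, the only measured step is a 1.3-fold higher number from compound 1 to compound 2 (0.10 log units; within the scatter), and it bears on this change only weakly, since it leaves the pyrrolidin-1-yl group untouched. Among the compounds with values here, no measured pair changes that group, so the data cannot fix the size of the coming step. Replacing a whole group may move the number further than that small step did. A shift beyond the scatter towards a lower number in this assay is the tentative expectation, a judgement rather than a measured trend. The expected change is a 2.4-fold lower number from compound 1 to compound 3 (0.38 log units; beyond the scatter). For compound 3 the estimated value is 50 ug/mL, with an expected range of 12 ug/mL to 180 ug/mL.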

Compound 3, half-maximal inhibitory concentration: 23 ug/mL
Beside the measured number, compound 3's estimate is 2.2-fold (0.34 log units) above it; measured number inside the range.
By their numbers in this assay, from the lowest: compound 3; then compounds 1 and 2 (each within the scatter of the next).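

In this assay, the group on the aromatic carbon ortho to two fluoro groups proves able to shift the number: 4-aminopiperidin-1-yl in place of pyrrolidin-1-yl gives a 5.2-fold lower number from compound 1 to compound 3 (0.72 log units; beyond the scatter), whereas methoxy in place of fluoro gave only a 1.3-fold higher number from compound 1 to compound 2 (0.10 log units; within the scatter). This is therefore the first change among these compounds to move the number beyond the scatter, and it moves towards stronger inhibition on this read-out, with a six-membered ring, more heavy atoms and a hydrogen-bond donor all entering in the same single step. No measurement shown accounts for the size of this step or separates those differences from one another.

The compounds shown leave open whether the amino group or the larger ring carries the step, a question that plain piperidin-1-yl and 3-aminopyrrolidin-1-yl on the same carbon could help to settle. They also leave open whether piperazin-1-yl would act like 4-aminopiperidin-1-yl here, and whether the step would hold with methoxy in place of the neighbouring fluoro group of the shared core.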